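Aryl to cyclohexyl at the chain end of an adenine series

A few compounds are considered here, and "the series" means these few. Any claim that something is new, unique, unknown or untested is made for them only; others in the source may bear on it.

Measured compounds:
- compound 1, `C[C@H](O)[C@@H](CCc1ccc(C(F)(F)F)cc1)n1cnc2c(N)ncnc21`, 5.2 nM
- compound 2, `C[C@H](O)[C@@H](CCc1cccc(F)c1)n1cnc2c(N)ncnc21`, 1.6 nM
- compound 3, `C[C@H](O)[C@@H](CCc1cccc(Br)c1)n1cnc2c(N)ncnc21`, 0.6 nM

In an assay on isolated protein for inhibition of adenosine deaminase (Bos taurus), with a stated time of 5 min (a higher number here means a weaker inhibitor, a lower number a stronger inhibitor), compound 3 gives the lowest of the three numbers. For the measured compounds named here, its nearest neighbour is compound 2, and the change from fluoro to bromo on the aromatic ring is the only one-place step among the measured compounds: a 2.7-fold lower number from compound 2 to compound 3 (0.43 log units; beyond the scatter). Going by the values given here, compound 1 stands furthest away, with its trifluoromethyl-bearing ring giving the highest number of the three; no single-place step links it to compound 3.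

Compound 4, `C[C@H](O)[C@@H](CCC1CCCCC1)n1cnc2c(N)ncnc21`, differs from compound 3 in one place: cyclohexyl in place of 3-bromophenyl on a saturated chain carbon, three bonds along the chain from an aromatic nitrogen. Among the compounds with values here, none of the measured steps changes an aromatic ring for a saturated one, so the step from compound 2 to compound 3 bears on it only by showing that what sits on the ring can move this assay beyond the scatter. On these data alone, whether a saturated ring without any halogen holds that position is untested, and a modest loss relative to compound 3 is considered the more likely outcome, though a number within the scatter of compound 3 cannot be ruled out. The estimated step is a 3.3-fold higher number from compound 3 to compound 4 (0.52 log units; beyond the scatter). For compound 4 a value of 2 nM is expected, with a range from 0.5 nM to 8 nM.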

Compound 4, inhibition constant: 1.9 nM
Compound 4: middle estimate off by 1.1-fold (0.02 log units), on the high side; the measured number falls inside the stated range.
By their numbers in this assay, from the lowest: compound 3; then compounds 2 and 4 (each within the scatter of the next); then compound 1.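

In this assay a saturated ring with no halogen holds this position, so an aromatic ring at the chain end is not a requirement among these compounds: a 1.2-fold higher number from compound 2 to compound 4 (0.07 log units; within the scatter) lies within the scatter, and cyclohexyl cannot be told apart here from 3-fluorophenyl. Against 3-bromophenyl the same change does register, as a 3.2-fold higher number from compound 3 to compound 4 (0.50 log units; beyond the scatter) lies beyond the scatter and is modest in size, so what the change from aryl to cyclohexyl costs depends on which aryl group it replaces. Nothing at hand gives a reason for either comparison, and the numbers alone do not separate the loss of the aromatic ring from the loss of the bromine.

The compounds shown leave open whether a bromo group placed on the cyclohexyl ring would bring the number closer to that of compound 3, which would help to separate those two contributions. They also leave open whether a smaller cyclopentyl ring, a piperidine ring carrying an amine, or a longer chain ahead of the cyclohexyl ring would be tolerated at this position.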